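Aryl Swap on the Triazole Nitrogen of a Spiro Series

The source may report more compounds than this note shows. Statements on the series, on what has been measured and on what is new or still open speak of the compounds shown alone.

Compound 1 `CCOc1ccccc1-n1nncc1CN1C(=O)C2(C(C#N)=C(N)Oc3c(N)cc4nc5ccccc5nc4c32)c2ccccc21`: 30500 nM
Compound 2 `Cc1cc(C)cc(-n2nncc2CN2C(=O)C3(C(C#N)=C(N)Oc4c(N)cc5nc6ccccc6nc5c43)c3ccccc32)c1`: > 50000 nM

Compound 1 `CCOc1ccccc1-n1nncc1CN1C(=O)C2(C(C#N)=C(N)Oc3c(N)cc4nc5ccccc5nc4c32)c2ccccc21` gives 30500 nM in a functional assay on HepG2 cells (Homo sapiens) for antiproliferative activity, read by MTT assay, with a stated time of 48 h; a higher number here means a weaker inhibitor, a lower number a stronger inhibitor. Compound 2 `Cc1cc(C)cc(-n2nncc2CN2C(=O)C3(C(C#N)=C(N)Oc4c(N)cc5nc6ccccc6nc5c43)c3ccccc32)c1` is reported in this assay only as a limit, > 50000 nM, so its place on the scale is known only as the limit of > 50000 nM in this assay, at which 1 of the 2 values shown sits. Among the measured compounds shown here, the one measured step, an at least 1.6-fold higher number from compound 1 to compound 2 (0.21 log units; that floor lies within the scatter), moved the value toward that limit but is itself of a size the scatter allows.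

Compound 3 `N#CC1=C(N)Oc2c(N)cc3nc4ccccc4nc3c2C12C(=O)N(Cc1cnnn1-c1cc(Cl)ccc1Cl)c1ccccc12` differs from compound 2 by 2,5-dichlorophenyl in place of 3,5-dimethylphenyl on an aromatic nitrogen. For the measured compounds named here, no measured step touches a dichlorophenyl group, and the only step at this aromatic nitrogen, an at least 1.6-fold higher number from compound 1 to compound 2 (0.21 log units; that floor lies within the scatter), sat within the scatter. The expectation for compound 3 is therefore a weak inhibitor in this assay, with the step of an at least 1.1-fold lower number from compound 2 to compound 3 (0.04 log units; that floor lies within the scatter) expected to stay within the scatter. Compound 3 is estimated at 45000 nM, within 15000 nM to 120000 nM.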

Compound 3, half-maximal inhibitory concentration: 33100 nM
Beside the measured number, compound 3's estimate is 1.4-fold (0.13 log units) above it; measured number inside the range.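

At this aromatic nitrogen, 2,5-dichlorophenyl and 2-ethoxyphenyl cannot be told apart in this assay, with a 1.1-fold higher number from compound 1 to compound 3 (0.04 log units; within the scatter). This adds a second measured value at the position, and the two aryl groups with measured values leave the result in the same place on the scale, whereas the earlier step could only be read against a limit. The step of an at least 1.5-fold lower number from compound 2 to compound 3 (0.17 log units; that floor lies within the scatter) is again only a floor, so it shows no firm separation, and compound 2 remains reported only as a limit: the limit of > 50000 nM in this assay, at which 1 of the 3 values shown sits.

The compounds shown leave open whether an aryl group carrying an amine or a carboxylic acid at this aromatic nitrogen, or a longer alkyl chain in place of the aryl group, would move the value beyond the scatter. They also leave open whether a change to the shared core would do so.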